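Replacing the 6-methoxypyridin-3-yl group of compound 2

The compounds below may be only part of what the source reports. "The series", "measured", "known", "first", "only" and "open" are said of these compounds alone.

Within the data shown here, in an ADME assay (liver) for metabolic stability, with Liver microsome (Rattus norvegicus) as the target, using microsomes and NADPH, with a stated time of 30 min, tested at 1 uM (a higher number here means faster removal of the compound, a lower number slower removal), compound 1 `Nc1ccc(S(=O)(=O)N2CCN(c3ncc(C(O)(C(F)(F)F)C(F)(F)F)cc3C#CCO)CC2)cn1` gives 65 mL.min-1.g-1, while compound 2 `COc1ccc(-c2cc(C(O)(C(F)(F)F)C(F)(F)F)cnc2N2CCN(S(=O)(=O)c3ccc(N)nc3)CC2)cn1` gives 265 mL.min-1.g-1, the higher of the two numbers so far. The two compounds differ in one place, with 6-methoxypyridin-3-yl in place of 3-hydroxyprop-1-yn-1-yl on an aromatic carbon. That change comes with a 4.1-fold higher number from compound 1 to compound 2 (0.61 log units; beyond the scatter), a modest step beyond the usual scatter.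

Compound 3 `Cc1nc2cc(-c3cc(C(O)(C(F)(F)F)C(F)(F)F)cnc3N3CCN(S(=O)(=O)c4ccc(N)nc4)CC3)ccc2o1` carries 2-methyl-1,3-benzoxazol-5-yl in place of 6-methoxypyridin-3-yl at that same aromatic carbon, and the rest of compound 2 stays unchanged: 2-methyl-1,3-benzoxazol-5-yl in place of 6-methoxypyridin-3-yl on an aromatic carbon. Among the measured compounds shown here, only one measured step bears on this change. It shows that the number can move with the group at this place, but it exchanges a hydroxypropynyl chain for an aromatic ring. No measured pair compares one aromatic ring group with another, so the direction of any shift is not shown by the data.

No clear step is therefore expected in this assay, and the expected change is a 1.1-fold higher number from compound 2 to compound 3 (0.04 log units; within the scatter). The estimated value for compound 3 is 290 mL.min-1.g-1, with an expected range of 130 mL.min-1.g-1 to 620 mL.min-1.g-1.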

Compound 3, intrinsic clearance in microsomes: 99 mL.min-1.g-1
Compound 3: the middle estimate sits 2.9-fold (0.47 log units) above what was measured; the measured number lies below the stated range.
By their numbers in this assay, from the lowest: compounds 1 and 3 (each within the scatter of the next); then compound 2.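

In this assay the choice among aromatic ring groups at this carbon matters: 2-methyl-1,3-benzoxazol-5-yl in place of 6-methoxypyridin-3-yl gives a 2.7-fold lower number from compound 2 to compound 3 (0.43 log units; beyond the scatter) in this series, so an aromatic ring at this place does not by itself set the number. The earlier step from the 3-hydroxyprop-1-yn-1-yl chain to an aromatic ring therefore does not hold in the same size for both ring groups, since the other comparison shows a 1.5-fold higher number from compound 1 to compound 3 (0.18 log units; within the scatter) and leaves compound 1 and compound 3 unseparated. Nothing given here explains the difference between the two aromatic ring groups.

The compounds shown leave open whether the shift follows from the loss of the methoxy group, from the loss of the ring nitrogen of the pyridine or from the fused five-membered ring, as these changes arrive together in compound 3. They also leave open how a plain phenyl ring, an amine or a carboxylic acid at this aromatic carbon, or a longer chain ending in a hydroxyl group, would compare.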